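The source may hold more compounds than are shown below. What is called first, only, known or untested is meant among the compounds shown, and "the series" means these compounds.

Compound 3, with the structure `COCCCn1c(N2CCN(C)CC2)nc2ccccc21`, gives 860 nM in a functional assay on ileum for inhibition of histamine H1 receptor (Cavia porcellus) (on this read-out higher numbers stand for weaker inhibition and lower numbers for stronger inhibition), and so stands highest of the three measured numbers. Its nearest neighbour is compound 1, `CCNCCn1c(N2CCN(C)CC2)nc2ccccc21`, which gives 290 nM; the furthest is compound 2, `CCCCCCn1c(N2CCN(C)CC2)nc2ccccc21`, which gives 26 nM. Compound 4, `CCCSCn1c(N2CCN(C)CC2)nc2ccccc21`, has not yet been measured, and the change that separates it from compound 3 is propylsulfanyl in place of 2-methoxyethyl on a saturated chain carbon bound to an aromatic nitrogen.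

For the measured compounds named here, two measured steps bear on this change. The step of a 33-fold higher number from compound 2 to compound 3 (1.52 log units; beyond the scatter) shows how strongly the numbers moved when an oxygen-bearing chain replaced an all-carbon one at a nearby place, and the step of a 3.0-fold higher number from compound 1 to compound 3 (0.47 log units; beyond the scatter) shows a smaller shift in the same direction when the oxygen-bearing chain replaced a nitrogen-bearing one. Compound 4 keeps a heteroatom in its chain but exchanges oxygen for sulfur and lengthens the carbon part, which sits between what compound 3 and compound 2 carry. A step of a 2.9-fold lower number from compound 3 to compound 4 (0.46 log units; beyond the scatter) is therefore expected, towards lower numbers but well short of the large swing seen in a 33-fold higher number from compound 2 to compound 3 (1.52 log units; beyond the scatter). Compound 4 is estimated at 300 nM, with a range from 60 nM to 1500 nM.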

Compound 4, half-maximal inhibitory concentration: 68 nM
Compound 4: middle estimate off by 4.4-fold (0.64 log units), on the high side; low and high end bracket the measured number.
By their numbers in this assay, from the lowest: compound 2; then compound 4; then compound 1; then compound 3.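

In this assay, the place on a saturated chain carbon bound to an aromatic nitrogen proved sensitive to a change that leaves the heavy-atom count and the hydrogen-bond acceptor count as they were: propylsulfanyl in place of 2-methoxyethyl gave a 13-fold lower number from compound 3 to compound 4 (1.10 log units; beyond the scatter). The earlier compounds shown here could have suggested that any heteroatom in this chain goes with higher numbers, but compound 4 does not fit that reading, since the step to it from the nitrogen-bearing chain is a 4.3-fold lower number from compound 1 to compound 4 (0.63 log units; beyond the scatter). The all-carbon chain of compound 2 still keeps the lowest number of the four, with a 2.6-fold higher number from compound 2 to compound 4 (0.42 log units; beyond the scatter), so the sulfur-bearing chain comes close to it without matching it.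

The step from compound 3 to compound 4 exchanges oxygen for sulfur and also rearranges the chain, from 3-methoxypropyl to (propylsulfanyl)methyl, and a propoxymethyl or a methylsulfanylpropyl chain would be needed to tell these two changes apart. No measurement at hand explains why the numbers moved as they did.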